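The source may report more compounds than this note shows. Statements on the series, on what has been measured and on what is new or still open speak of the compounds shown alone.

Compounds measured in a functional assay on Jurkat cells (Homo sapiens) for activation, with a stated time of 24 h; on this read-out higher numbers stand for an effect only at larger amounts of compound and lower numbers for an effect already at smaller amounts:
compound 1 `Oc1ccccc1CNc1ccc(-c2ccccc2)cc1` — 1820 nM
compound 2 `Oc1ccccc1CNc1ccc(-c2ccc(Cl)cc2)cc1` — 2390 nM
compound 3 `Oc1ccccc1CNc1ccc(-c2ccc(C(F)(F)F)cc2)cc1` — "not active" (no number reported)

Compound 2 and compound 1 sit within the scatter of each other, since the step of a 1.3-fold higher number from compound 1 to compound 2 (0.12 log units; within the scatter) is small; compound 3 gave no number at all. Compound 4 `Oc1ccccc1CNc1ccc(-c2ccccc2F)cc1` differs from compound 2 by 2-fluorophenyl in place of 4-chlorophenyl on an aromatic carbon. For the measured compounds named here, no measured step matches this change directly: the only single step, a 1.3-fold higher number from compound 1 to compound 2 (0.12 log units; within the scatter), concerns chloro against hydrogen and stayed within the scatter, while compound 3 shows that a trifluoromethyl at the same place lost activity. The expectation for compound 4 is therefore a number close to compound 2, with wide uncertainty. Compound 4 is estimated at 2000 nM (range 700 nM to 6000 nM), a step of a 1.2-fold lower number from compound 2 to compound 4 (0.08 log units; within the scatter) that is expected to remain within the scatter.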

Compound 4, half-maximal effective concentration: 2150 nM
Compound 4: middle estimate off by 1.1-fold (0.03 log units), on the low side, and the stated range covers the measured number.
By their numbers in this assay, from the lowest: compounds 1, 4 and 2 (each within the scatter of the next).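

In this assay the 2-fluorophenyl group of compound 4 sits within the scatter of both relatives, with a 1.1-fold lower number from compound 2 to compound 4 (0.05 log units; within the scatter) and with a 1.2-fold higher number from compound 1 to compound 4 (0.07 log units; within the scatter). So a halogen on this ring can sit at a second place, not only where compound 2 carries its chloro, and still give a number, which compound 3 with trifluoromethyl did not. Nothing available explains this result. Going by these compounds, whether an amine, a methoxy or a carboxylic acid at this place would still give a number stays open. So does whether trifluoromethyl would give one here.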